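This account rests on a few compounds, and the source may have more. Where it says the series, first, only, none or still open, it means among the compounds named here.

Of the compounds shown here, three sharing one core have been tested in a functional assay on HCT-116 cells (Homo sapiens) for cytotoxicity, read by MTT assay, with a stated time of 48 h; on this read-out higher numbers stand for weaker inhibition and lower numbers for stronger inhibition. Compound 1 (`COc1cc(/C=C/C(=O)C2=C(/C=C/c3ccc(O)c(OC)c3)NC(=O)NC2c2ccc(C)cc2)ccc1O`) gives 50000000 nM, compound 2 (`COc1cc(/C=C/C(=O)C2=C(/C=C/c3ccc(O)c(OC)c3)NC(=O)NC2c2ccc(O)cc2)ccc1O`) gives 12500000 nM, and compound 3 (`COc1cc(/C=C/C(=O)C2=C(/C=C/c3ccc(O)c(OC)c3)NC(=O)NC2c2ccccc2)ccc1O`) gives 25000000 nM. Compound 3 cannot be told apart from either of the others: the data show a 2.0-fold lower number from compound 1 to compound 3 (0.30 log units; within the scatter) and a 2.0-fold higher number from compound 2 to compound 3 (0.30 log units; within the scatter). Only the outer pair separates, with a 4.0-fold lower number from compound 1 to compound 2 (0.60 log units; beyond the scatter).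

Compound 4 (`COc1cc(/C=C/C(=O)C2=C(/C=C/c3ccc(O)c(OC)c3)NC(=O)NC2c2ccccc2O)ccc1O`) departs from compound 3 by a single change, hydroxy in place of hydrogen on an aromatic carbon, ortho to a large group, which turns phenyl into 2-hydroxyphenyl. The closest evidence is a 2.0-fold higher number from compound 2 to compound 3 (0.30 log units; within the scatter), the same exchange of groups read in reverse, although compound 2 carries its hydroxy at another place on that ring. The two steps from compound 1 involve methyl and bear on this change only indirectly. No step beyond the scatter is therefore expected in this assay, with only a slight lean towards a lower number. The expected change is a 1.7-fold lower number from compound 3 to compound 4 (0.22 log units; within the scatter). For compound 4 the estimated value is 15000000 nM, with an expected range from 5000000 nM to 50000000 nM.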

Compound 4, half-maximal inhibitory concentration: 100000000 nM
Compound 4: the middle estimate sits 6.7-fold (0.82 log units) below what was measured; the measured number lies above the stated range.
By their numbers in this assay, from the lowest: compounds 2, 3, 1 and 4 (each within the scatter of the next, the first and the last beyond it).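

In this assay the step of a 4.0-fold higher number from compound 3 to compound 4 (0.60 log units; beyond the scatter) shows that hydroxy in place of hydrogen on this aromatic carbon, ortho to a large group, can be told from the scatter, which the earlier comparison of 4-hydroxyphenyl with phenyl could not show. The place of the hydroxy on the ring also counts here, as the step of an 8.0-fold higher number from compound 2 to compound 4 (0.90 log units; beyond the scatter) separates 2-hydroxyphenyl from 4-hydroxyphenyl and runs opposite to the slight lean seen for the 4-hydroxyphenyl compound. Against 4-methylphenyl, however, 2-hydroxyphenyl cannot be told apart, with the step of a 2.0-fold higher number from compound 1 to compound 4 (0.30 log units; within the scatter) leaving these two compounds level in this read-out.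

The compounds shown offer nothing that accounts for this dependence on the place of the hydroxy. They also leave open whether the higher number belongs to hydroxy itself or to any group on this aromatic carbon, since methoxy, an amine or fluorine on the same carbon do not appear among them.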